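The source may report more compounds than this note shows. Statements on the series, on what has been measured and on what is new or still open speak of the compounds shown alone.

Measured so far:
- compound 1, `O=C1/C(=C/c2ccncc2)CN(S(=O)(=O)c2ccc(Br)cc2)C/C1=C\c1ccccc1F`: 19400 nM
- compound 2, `N#Cc1ccc(S(=O)(=O)N2C/C(=C\c3ccncc3)C(=O)/C(=C/c3ccccc3F)C2)cc1`: > 20000 nM
- compound 3, `O=C1/C(=C/c2cccnc2)CN(S(=O)(=O)c2ccc(Br)cc2)C/C1=C\c1ccccc1C(F)(F)F`: 13300 nM

Of the compounds shown here, three have been tested in an ADME assay on L02 cells (Homo sapiens) for cytotoxicity, read by MTT assay, with a stated time of 24 h (a lower number here means a stronger inhibitor, a higher number a weaker inhibitor), and a fourth, compound 4, `N#Cc1ccc(S(=O)(=O)N2C/C(=C\c3cccnc3)C(=O)/C(=C/c3ccccc3C(F)(F)F)C2)cc1`, has not. The value given for compound 2 is a limit of this assay, not a measured number, and that needs to be kept in mind throughout, since (the limit of > 20000 nM in this assay, at which 1 of the 3 values shown sits).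

Compound 1 and compound 2 share one core and differ only in the change (cyano in place of bromo on an aromatic carbon). That change gave an at least 1.0-fold higher number from compound 1 to compound 2 (0.01 log units; that floor lies within the scatter), so on this core the two results cannot be told apart. Compound 3 and compound 4 share a second core, and the difference between the two cores is not broken down here. Between compound 3 and compound 4 the same change is made, (cyano in place of bromo on an aromatic carbon), at the same place in both pairs.

What is known rests on a single pair, and in that pair the second member reached only a limit. The step from compound 3 to compound 4 is therefore expected to be small, estimated at a 1.3-fold higher number from compound 3 to compound 4 (0.11 log units; within the scatter), on the grounds that the same change from compound 1 to compound 2 gave an at least 1.0-fold higher number from compound 1 to compound 2 (0.01 log units; that floor lies within the scatter). Compound 4 is accordingly expected to come out near 17000 nM in this assay, with a range from 8500 nM to 40000 nM, and with a real chance that the assay again reports only a limit rather than a number.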

Compound 4, half-maximal inhibitory concentration: 13200 nM
Beside the measured number, compound 4's estimate is 1.3-fold (0.11 log units) above it; the measured number falls inside the stated range.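

In this assay, the swap of bromo for cyano on the second core gives a 1.0-fold lower number from compound 3 to compound 4 (0.00 log units; within the scatter), so the two members of this pair cannot be told apart and the swap shows no measurable effect here. Set beside the first pair, this result gives no sign that the change acts differently on the two cores, but it cannot settle the matter: the same change on two cores in this assay, an at least 1.0-fold higher number (0.01 log units; that floor lies within the scatter) from compound 1 to compound 2 and a 1.0-fold lower number (0.00 log units; within the scatter) from compound 3 to compound 4; the limit leaves it open whether they differ

Compound 2 reads > 20000 nM, which is a limit of the assay and not a number, so the first pair gives no exact size for the change, and two pairs, only one of them fully measured, do not prove that the change carries over unaltered from one core to the other or to any further core.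

The compounds shown carry only bromo or cyano at this place on the aromatic ring, so they leave open what an amine or a carboxylic acid there would do in this assay. They also leave open how the same swap would behave on a core other than these two, and what number compound 2 would give if the assay could report one.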